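The compounds below may be only part of what the source reports. "The series", "measured", "known", "first", "only" and "open" are said of these compounds alone.

Working notes on the series. Compound 1 `Cc1cc(-c2ccccc2)nnc1NCCCN` and compound 2 `Cc1cc(-c2ccccc2)nnc1NCCN` share one core and differ only in the saturated chain that carries the terminal nitrogen. In a functional assay on the whole organism with Mus musculus as the target (a higher number here means that more compound is needed for the effect, a lower number that less compound is needed), compound 1 gives 0.1 mg/kg. In this assay compound 2 gives 0.5 mg/kg, the highest of the two numbers measured, and the step of a 5.0-fold higher number from compound 1 to compound 2 (0.70 log units; beyond the scatter) is beyond the scatter, so the shorter chain of compound 2 asks for more compound. Compound 3 `Cc1cc(-c2ccccc2)nnc1NCCCCN` is not yet measured. The change 2-aminoethyl in place of amino on a saturated chain carbon, two bonds along the chain from a nitrogen on an aromatic ring runs in the opposite sense to that step, lengthening the chain past the length found in compound 1. Only the step from compound 1 to compound 2 bears on it; it is modest, and whether a further extension continues the trend or turns back is not shown by any measured pair. The expected step is a 3.3-fold lower number from compound 2 to compound 3 (0.52 log units; beyond the scatter), a lower number, of about the size already seen. Compound 3 is estimated at 0.15 mg/kg, within 0.05 mg/kg to 0.6 mg/kg.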

Compound 3, minimum effective dose: 0.1 mg/kg
Estimate against measurement, compound 3: 1.5-fold (0.18 log units) above; measured number inside the range.
By their numbers in this assay, from the lowest: compounds 1 and 3 (each within the scatter of the next); then compound 2.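

On the saturated chain, two bonds along from a nitrogen on an aromatic ring, 2-aminoethyl in place of amino gives in this assay a 5.0-fold lower number from compound 2 to compound 3 (0.70 log units; beyond the scatter), so the step seen earlier is not tied to compound 1 alone. Three bonds along the chain, aminomethyl in place of amino gives no change at the digits printed from compound 1 to compound 3 (within the scatter), so the trend from compound 2 to compound 1 does not continue with the longer chain of compound 3. Among these three chains, only compound 2 stands apart, with both of its steps beyond the scatter.

Nothing on hand explains why the numbers follow the chain in this way. Still open, on these data alone, is whether a longer chain, a branched chain or a dimethylamino group at the chain end would keep the number shared by compound 1 and compound 3.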